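Thiophen-2-yl to furan-2-yl: expectations for compound 3

The source may hold more compounds than are shown below. What is called first, only, known or untested is meant among the compounds shown, and "the series" means these compounds.

Working notes on the series. For the measured compounds named here, in a functional assay on PC-3 cells (Homo sapiens) for inhibition, read by sulforhodamine B assay, with a stated time of 48 h, tested at 50 uM (a lower number here means less inhibition of growth, a higher number more inhibition of growth at the concentration tested), compound 1 (`COc1cc(/C=C/C(=O)/C=C/c2cccs2)ccc1OCc1cn(CCOc2cc(=O)oc3ccccc23)nn1`) gives 12%, the only number available so far. Going by the values given here, compound 2 (`COc1cccc(/C=C/C(=O)/C=C/c2ccc(OCc3cn(CCCCCOc4cc(=O)oc5ccccc45)nn3)c(OC)c2)c1`) is reported as "not active" (no number reported), so no numerical comparison with compound 1 is possible, and no measured step exists to calibrate the next change.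

The next compound, compound 3 (`COc1cc(/C=C/C(=O)/C=C/c2ccco2)ccc1OCc1cn(CCOc2cc(=O)oc3ccccc23)nn1`), keeps the core of compound 1 and carries furan-2-yl in place of thiophen-2-yl on a double-bonded chain carbon bound to a double-bonded chain carbon. The exchange leaves the counted features of the group unchanged apart from the hetero atom. With compound 1 at 12% as the sole anchor, no step beyond the scatter is expected in this assay, and no direction is favoured. The expected size is no change at the digits printed from compound 1 to compound 3 (within the scatter). For compound 3 the estimate is 12%, with an expected range from 0% to 28%.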

Compound 3, percent growth inhibition at one concentration: 14%
Compound 3: middle estimate off by 2 percentage points, on the low side; measured number inside the range.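

In this assay, for the compounds shown here, the exchange of thiophen-2-yl for furan-2-yl on a double-bonded chain carbon bound to a double-bonded chain carbon gives the first measured step, a number 2 percentage points higher from compound 1 to compound 3 (within the scatter). Sulfur and oxygen as the ring hetero atom are therefore not told apart at this place in this read-out, at least for a five-membered aromatic ring with the same counted features. Nothing available explains why the two compounds read alike.

From the compounds shown here alone, whether a group of another kind at this place, such as a phenyl ring carrying an amine or a carboxylic acid, would move the value beyond the scatter remains open. Also open, going by these compounds, is whether the parity between these two rings would hold in a second cell line or at another concentration.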